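Compound 1 to compound 3: fluoro to diethylamino

The source may report more compounds than this note shows. Statements on the series, on what has been measured and on what is new or still open speak of the compounds shown alone.

- Compound 1 `COc1ccc(/C=C/c2ccc3ccccc3c2)cc1F`: > 5000 nM (a limit)
- Compound 2 `COc1cc(/C=C\c2ccc3ccccc3c2)ccc1F`: 450 nM

In a functional assay on HCT-116 cells (Homo sapiens) for inhibition (on this read-out higher numbers stand for weaker inhibition and lower numbers for stronger inhibition), compound 1 gives > 5000 nM, which is a limit of the assay and not a number. Compound 1 therefore stands at the limit of > 5000 nM in this assay, at which 1 of the 2 values shown sits. Compound 2 gives 450 nM, a measured number.

Compound 3 `CCN(CC)c1cc(/C=C/c2ccc3ccccc3c2)ccc1OC` differs from compound 1 in one place: diethylamino in place of fluoro on an aromatic carbon. This puts diethylamino in place of fluoro on an aromatic carbon, ortho to a methoxy group.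

For the measured compounds named here, no two measured compounds here differ in one place only, so the size of this change has no measured reference. The expected step is a number no higher from compound 1 to compound 3 (the limit leaves the size open), small and with no firm direction, and it is not expected to go clearly beyond the scatter. A result reported only as a limit is somewhat more likely than a number. Compound 3 is estimated at 5000 nM, with an expected range of 1500 nM to 10000 nM.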

Compound 3, half-maximal inhibitory concentration: > 5000 nM
Compound 3 ended at the assay's limit; the forecaster's own chance of this, stated with the estimate: 55%; the middle value lies on the limit itself.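

In this assay compound 3 gives > 5000 nM as a limit of the assay and not a number. For the compounds shown here, compound 1 likewise gives > 5000 nM as a limit, so no step from compound 1 to compound 3 can be read. Still open, as far as these compounds go, is whether diethylamino in place of fluoro on an aromatic carbon changes inhibition in either direction.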